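The compounds below may be only part of what the source reports. "The series", "measured", "known", "first", "only" and "open" are said of these compounds alone.

In a physicochemical assay, with a stated time of 6 min (on this read-out lower numbers stand for stronger inhibition and higher numbers for weaker inhibition), compound 1 (`O=C(Nc1nc(-c2cc3ccccc3o2)cs1)Nc1ccccc1F`) gives 2630 nM as a measured number. Compound 2 (`O=C(Nc1ccc([N+](=O)[O-])cc1)Nc1nc(-c2cc3cc(Br)ccc3o2)cs1`) is recorded at > 200000 nM and that entry is a limit of the assay, not a number. Compound 2 therefore has no exact position on this scale. Compound 3 (`O=C(Nc1nc(-c2cc3cc(Br)ccc3o2)cs1)Nc1ccccc1F`) departs from compound 2 in one place, with 2-fluorophenyl in place of 4-nitrophenyl on an amide-type nitrogen. Among the compounds with values here, no step between measured compounds that differ in one place is available, so the size of this change has not been seen directly. Within the data shown here, the entering 2-fluorophenyl is also carried by compound 1, which gives 2630 nM in this assay and is the only measured number to lean on. A large move toward stronger inhibition is therefore expected. The expected change is an at least 66-fold lower number from compound 2 to compound 3 (1.82 log units; beyond the scatter) and its size is only an estimate set against a limit. Compound 3 is estimated at 3000 nM in this assay with 700 nM to 15000 nM as the expected range.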

Compound 3, half-maximal inhibitory concentration: > 200000 nM
Compound 3: a limit, no number; the forecaster's own chance of this, stated with the estimate: 10%; at least 66-fold (1.82 log units) between middle value and limit.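

In this assay, within the data shown here, the one step that can be read is bromo in place of hydrogen on an aromatic carbon, an at least 76-fold higher number from compound 1 to compound 3 (1.88 log units; beyond the scatter), with the 2-fluorophenyl on the amide-type nitrogen held the same. Among these compounds, compound 1 and compound 2 differ in two places, so the earlier compounds could not separate these changes; this pair ties the loss of a measurable number to the bromo alone. Swapping 4-nitrophenyl for 2-fluorophenyl did not bring a measurable number back on the bromo core, but compound 2 and compound 3 both stand at a limit and not at a number, so the step between them cannot be read, and the two compounds share one edge of the scale: the limit of > 200000 nM in this assay, at which 2 of the 3 values shown sit.

Going by these compounds, how the 4-nitrophenyl group behaves on the core of compound 1, which carries hydrogen in place of bromo, remains open, so its effect on the group at the amide-type nitrogen has no reading yet. Also open, on these data alone, is whether chloro or methoxy in place of bromo on that aromatic carbon would give a measurable number in this assay.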